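The compounds below may be only part of what the source reports. "The series", "measured", "known", "first", "only" and "open" are said of these compounds alone.

Among the measured compounds shown here, only two compounds have been measured so far in a functional assay (Mus musculus) for inhibition, with a stated time of 5 days; on this read-out lower numbers stand for stronger inhibition and higher numbers for weaker inhibition. Compound 2 `O=C(O)/C=C/c1cn(-c2ccc(O)cc2)nc1-c1ccc(O)c(O)c1` gives > 100000 nM, which is a limit of the assay and not a number. Compound 1 `CCOC(=O)/C=C/c1cn(-c2ccc(O)cc2)nc1-c1cccc(O)c1` does give a number, 14000 nM.

Compound 3 `CCOC(=O)/C=C/c1cn(-c2ccc(O)cc2)nc1-c1ccc(O)c(O)c1` is compound 2 with a single change: ethyl in place of hydrogen on an oxygen next to a carbonyl group. Put another way, carboxy becomes ethoxycarbonyl, so the 2-carboxyethenyl group turns into 2-(ethoxycarbonyl)ethenyl.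

For the measured compounds named here, no measured pair of compounds shows this change on its own, so the size of the step has to be judged indirectly. Going by the values given here, the only guide is compound 1, which carries the same 2-(ethoxycarbonyl)ethenyl group and gives 14000 nM in this assay. On that basis, compound 3 is expected to land near compound 1 rather than at the limit. The estimated step of an at least 8.3-fold lower number from compound 2 to compound 3 (0.92 log units; beyond the scatter) points toward stronger inhibition and is expected to lie beyond the usual scatter. For compound 3 the expected value is 12000 nM, with an estimated range from 4000 nM to 40000 nM.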

Compound 3, half-maximal inhibitory concentration: 6200 nM
Estimate against measurement, compound 3: 1.9-fold (0.29 log units) above; the measured number falls inside the stated range.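

In this assay, among the compounds shown here, ethyl in place of hydrogen on an oxygen next to a carbonyl group, which turns carboxy into ethoxycarbonyl, gives an at least 16-fold lower number from compound 2 to compound 3 (1.20 log units; beyond the scatter), the first direct reading of this change on its own. Compound 2 gives a limit of the assay and not a number, so this step can only be read as a minimum: the limit of > 100000 nM in this assay, at which 1 of the 3 values shown sits.

With the 2-(ethoxycarbonyl)ethenyl group held the same, hydroxy in place of hydrogen on an aromatic carbon gives a 2.3-fold lower number from compound 1 to compound 3 (0.35 log units; beyond the scatter), a modest step beside the large one seen at the carboxy group.

The compounds shown cannot tell whether ethyl itself matters or whether a methyl group or a longer chain on that oxygen would serve equally well, and an amide in place of the ethoxycarbonyl group remains a further open case. Nor do they show whether the step from carboxy to ethoxycarbonyl would have a similar size on the core of compound 1, which carries one hydroxy group fewer.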